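Changing the phenyl group on a ring nitrogen

The source may report more compounds than this note shows. Statements on the series, on what has been measured and on what is new or still open speak of the compounds shown alone.

Of the compounds shown here, two have so far been measured in an assay on HEK293 cells for inhibition of Voltage-dependent T-type calcium channel subunit alpha-1G (Homo sapiens), read by fluorescence, tested at 10 uM; a higher number here means more inhibition at the concentration tested (going by the name of the read-out), a lower number less inhibition. Compound 1 `CCCc1nc(-c2ccccc2)c(CNCCCN2CCN(c3ccccc3C(F)(F)F)CC2)o1` gives 45%, and compound 2 `CCCc1nc(-c2ccccc2)c(CNCCCN2CCN(c3cccc(C)c3)CC2)o1` gives 47.8%. Of these two numbers compound 2 has the higher one, but the step of a number 2.8 percentage points higher from compound 1 to compound 2 (within the scatter) is within the scatter, so the two compounds cannot be separated on this assay. That step exchanged one substituted phenyl group for another on the same amine nitrogen in a ring.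

Compound 3 `CCCc1nc(-c2ccccc2)c(CNCCCN2CCN(c3ccccc3F)CC2)o1` has not yet been measured. It differs from compound 2 in one place: 2-fluorophenyl in place of 3-methylphenyl on an amine nitrogen in a ring. Among the measured compounds shown here, this is again an exchange of one substituted phenyl group for another at the same position, so the only measured step that bears on it is a number 2.8 percentage points higher from compound 1 to compound 2 (within the scatter), which stayed within the scatter. On that basis no step beyond the scatter is expected in this assay, and the expected step is a number 1.8 percentage points lower from compound 2 to compound 3 (within the scatter). Compound 3 is therefore estimated at 46%, with an expected range from 30% to 62%.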

Compound 3, a percentage reported as inhibition, at one concentration (the size of the read-out at that concentration, not a potency): 54.4%
For compound 3 the middle estimate is 8.4 percentage points below the measured one; the measured number falls inside the stated range.
By their numbers in this assay, from the lowest: compounds 1, 2 and 3 (each within the scatter of the next).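

The exchange of 3-methylphenyl for 2-fluorophenyl on the amine nitrogen in a ring gives a number 6.6 percentage points higher from compound 2 to compound 3 (within the scatter) in this assay, and fluoro in place of trifluoromethyl on the same aromatic carbon gives a number 9.4 percentage points higher from compound 1 to compound 3 (within the scatter) as its step. The second of these adds something new, as it changes only the substituent on the phenyl group, and even this exchange does not separate the two compounds. Across these three substituted phenyl groups, then, no step at this position lies beyond the scatter, and nothing at hand accounts for the small differences that are printed.

Still open, going by these compounds, is whether an unsubstituted phenyl, a pyridyl or a methoxyphenyl group on the same nitrogen would give a step beyond the scatter in this assay as well. These compounds also say nothing about the rest of the molecule, such as a butyl chain in place of the propyl group or an amide in place of the open-chain amine.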